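Sulfonyl acid in place of the pyridine amide

The source may report more compounds than this note shows. Statements on the series, on what has been measured and on what is new or still open speak of the compounds shown alone.

Compound 1 `O=C(c1cccnc1)N1CCC(NS(=O)(=O)c2cc(S(=O)(=O)c3ccccc3)ccc2C(F)(F)F)CC1` gives 80 nM in an assay on isolated protein for displacement of a labelled ligand from secreted frizzled-related protein 1 (Homo sapiens), read by fluorescence polarization, with a stated time of 30 min; a lower number here means a stronger inhibitor, a higher number a weaker inhibitor.
Compound 2 `O=C(c1ccc(Cl)nc1)N1CCC(NS(=O)(=O)c2cc(S(=O)(=O)c3ccccc3)ccc2C(F)(F)F)CC1` gives 110 nM in this assay.
Compound 3 `CN(C)c1ccc(C(=O)N2CCC(NS(=O)(=O)c3cc(S(=O)(=O)c4ccccc4)ccc3C(F)(F)F)CC2)cn1` gives 40 nM in this assay.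

Of the three measured compounds, compound 3 has the lowest number. Its nearest neighbour is compound 1, with a 2.0-fold lower number from compound 1 to compound 3 (0.30 log units; within the scatter); compound 2 lies further off, with a 2.8-fold lower number from compound 2 to compound 3 (0.44 log units; beyond the scatter). The remaining step, a 1.4-fold higher number from compound 1 to compound 2 (0.14 log units; within the scatter), is small.

Compound 4 `O=C(O)c1cccc(S(=O)(=O)N2CCC(NS(=O)(=O)c3cc(S(=O)(=O)c4ccccc4)ccc3C(F)(F)F)CC2)c1` differs from compound 3 in one place: (3-carboxyphenyl)sulfonyl in place of (6-(dimethylamino)pyridin-3-yl)carbonyl on an amine nitrogen in a ring. For the measured compounds named here, none of the measured steps bears on this change. All three steps alter only the substituent on the pyridine ring of the (6-(dimethylamino)pyridin-3-yl)carbonyl group, while compound 4 exchanges that whole group, including the carbonyl link, for a sulfonyl-linked carboxyphenyl. Going by the values given here, the measured steps are all modest in size, so the shared core appears to carry much of the activity, but a change of this kind has no precedent here, and the expectation is accordingly wide. Compound 4 is estimated at 150 nM, with a range from 40 nM to 600 nM, which is an expected step of a 3.8-fold higher number from compound 3 to compound 4 (0.57 log units; beyond the scatter).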

Compound 4, half-maximal inhibitory concentration: 20 nM
The estimate for compound 4 lay 7.5-fold (0.88 log units) above the measured number; measured number outside the range, below it.
By their numbers in this assay, from the lowest: compounds 4, 3, 1 and 2 (each within the scatter of the next, the first and the last beyond it).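

The amine nitrogen in the ring tolerates replacement of the whole group it carries, link included: in this assay there is a 2.0-fold lower number from compound 3 to compound 4 (0.30 log units; within the scatter) and so no separation between (3-carboxyphenyl)sulfonyl and (6-(dimethylamino)pyridin-3-yl)carbonyl. Against the other two pyridine carbonyl groups the same exchange goes beyond the scatter, with a 4.0-fold lower number from compound 1 to compound 4 (0.60 log units; beyond the scatter) and a 5.5-fold lower number from compound 2 to compound 4 (0.74 log units; beyond the scatter), which shows that this position is not limited to the carbonyl-linked pyridines of the earlier compounds. Nothing measured here accounts for this result.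

The compounds shown leave open whether the sulfonyl link or the carboxylic acid matters more, as the two enter together. A phenylsulfonyl group without the acid, a carboxybenzoyl group, or a methyl ester or primary amide in place of the acid would separate these parts.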